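Shortening the nitrate-bearing chain on a triazolethione hydrazide

The source may report more compounds than this note shows. Statements on the series, on what has been measured and on what is new or still open speak of the compounds shown alone.

Measured compounds:
- compound 1, `CC(C)Cc1ccc(C(C)c2n[nH]c(=S)n2-c2ccc(C(=O)NNC(=O)CO[N+](=O)[O-])c(C(=O)NNC(=O)CO[N+](=O)[O-])c2)cc1` — 38.7 ug/mL
- compound 2, `CC(C)Cc1ccc(C(C)c2n[nH]c(=S)n2-c2ccc(C(=O)NNC(=O)CCO[N+](=O)[O-])cc2)cc1` — 30.5 ug/mL

Two compounds have numbers in a functional assay on aorta (Rattus norvegicus, strain Wistar albino) for inhibition; on this read-out higher numbers stand for an effect only at larger amounts of compound and lower numbers for an effect already at smaller amounts. Compound 2 gives 30.5 ug/mL, the lowest of the two; compound 1 gives 38.7 ug/mL, a value that lies within the scatter of that of compound 2, so the two cannot be told apart on this read-out.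

Compound 3, `CC(C)Cc1ccc(C(C)c2n[nH]c(=S)n2-c2ccc(C(=O)NNC(=O)CO[N+](=O)[O-])cc2)cc1`, has not been measured. It differs from compound 2 by nitrooxy in place of (nitrooxy)methyl on a saturated chain carbon bound to a carbonyl carbon. For the measured compounds named here, no step between measured compounds shows this change on its own. Compound 1 carries the same (nitrooxy)methyl chain as compound 3, and its value sits within the scatter of compound 2, so nothing in hand points to a shift beyond the scatter in either direction. Compound 3 is therefore expected to give about 35 ug/mL, within 18 ug/mL to 70 ug/mL, a step of a 1.1-fold higher number from compound 2 to compound 3 (0.06 log units; within the scatter) that is expected to stay within the usual scatter.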

Compound 3, half-maximal effective concentration: 42.8 ug/mL
For compound 3 the middle estimate is 1.2-fold (0.09 log units) below the measured one, and the stated range covers the measured number.
By their numbers in this assay, from the lowest: compounds 2, 1 and 3 (each within the scatter of the next).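

In this assay, the change to nitrooxy in place of (nitrooxy)methyl on a saturated chain carbon bound to a carbonyl carbon gives a 1.4-fold higher number from compound 2 to compound 3 (0.15 log units; within the scatter), so the read-out does not separate these two chain lengths at this position. The replacement of ((((nitrooxy)methyl)carbonyl)amino)carbamoyl by hydrogen on an aromatic carbon can now also be read on its own, and it gives a 1.1-fold higher number from compound 1 to compound 3 (0.04 log units; within the scatter), so that group makes no difference that this read-out can resolve. No other measurement bears on why these steps are this small.

The compounds shown leave open whether a longer chain, such as 3-(nitrooxy)propyl, would give a step beyond the scatter. They also leave open whether a hydroxy group or a carboxylic acid in place of the nitrooxy group would do so.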